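Two Ester Variants and a Ring-Bearing Newcomer

The source may report more compounds than this note shows. Statements on the series, on what has been measured and on what is new or still open speak of the compounds shown alone.

Compound 1: `C=CCOC(=O)C1=C(C)NC(C)=C(C(=O)OC)C1c1ccccc1[N+](=O)[O-]` — 8 nM
Compound 2: `C=C(C)CCOC(=O)C1=C(C)NC(C)=C(C(=O)OC)C1c1cccc([N+](=O)[O-])c1` — 23 nM

Both compounds were tested in a functional assay on HEK293 cells for antagonist activity at Voltage-dependent L-type calcium channel subunit alpha-1C (Oryctolagus cuniculus), read by FLIPR; a higher number here means a weaker inhibitor, a lower number a stronger inhibitor. Compound 2 gives the higher of the two numbers; the lower number of compound 1 lies beyond the scatter, so compound 1 is the stronger inhibitor here. Compound 3, `COC(=O)C1=C(C)NC(C)=C(C(=O)OC2C=CCCC2)C1c1cccc([N+](=O)[O-])c1`, has not been measured. It differs from compound 2 only in one place: cyclohex-2-en-1-yl in place of 3-methylbut-3-en-1-yl on an oxygen next to a carbonyl group. Within the data shown here, with no comparable step among the measured compounds, the change a 1.5-fold lower number from compound 2 to compound 3 (0.19 log units; within the scatter) is expected to stay within the scatter, in either direction. Compound 3 is therefore estimated at 15 nM, with a plausible range from 5 nM to 50 nM.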

Compound 3, half-maximal inhibitory concentration: 10 nM
Compound 3: middle estimate off by 1.5-fold (0.18 log units), on the high side, and the stated range covers the measured number.
By their numbers in this assay, from the lowest: compounds 1 and 3 (each within the scatter of the next); then compound 2.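

At this position, on an oxygen next to a carbonyl group, the first measured step shows that the ester side chain can be changed without losing activity. In this assay, cyclohex-2-en-1-yl in place of 3-methylbut-3-en-1-yl gives a 2.3-fold lower number from compound 2 to compound 3 (0.36 log units; beyond the scatter), so a six-membered ring of carbon only is accepted here and an open chain is not required. No measurement available here explains this difference.

On these data alone, it remains open whether the double bond in the ring matters, as a plain cyclohexyl group would show. Also open, as far as these compounds go, is how a chain carrying an amine would fare at this position.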